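The source may hold more compounds than are shown below. What is called first, only, known or untested is meant among the compounds shown, and "the series" means these compounds.

In a functional assay on BMDM cells (Mus musculus, strain C57BL/6) for inhibition, with a stated time of 2 days (on this read-out lower numbers stand for stronger inhibition and higher numbers for weaker inhibition), the measured compounds are these.
Compound 1 `Cc1cc(NC(=O)Cn2cc(-c3ccc(Cl)cc3)nn2)no1` gives 1910 nM.
Compound 3 `Cc1csc(NC(=O)Cn2cc(-c3ccc(Cl)cc3)nn2)n1` gives 520 nM.
Compound 2 `COc1ccc(-c2cn(CC(=O)Nc3cc(C)on3)nn2)cc1` reaches only the limit of this assay, > 30000 nM.

Compound 1 holds the highest of the two numbers shown; its nearest neighbour is compound 3, with a step of a 3.7-fold lower number from compound 1 to compound 3 (0.57 log units; beyond the scatter), a change on the amide-type nitrogen. Among the compounds with values here, the only change on the aryl group is that from compound 1 to compound 2, an at least 15-fold higher number from compound 1 to compound 2 (1.19 log units; beyond the scatter), where the value sits at the limit of > 30000 nM in this assay, at which 1 of the 3 values shown sits.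

Compound 4 `Cc1cc(NC(=O)Cn2cc(-c3cccs3)nn2)no1` differs from compound 1 in one place: thiophen-2-yl in place of 4-chlorophenyl on an aromatic carbon. This touches the same aryl position that was altered from compound 1 to compound 2, and there the exchange of the chloro group cost a large amount of potency. The thiazole step from compound 1 to compound 3 lies elsewhere and does not speak to this change. The expectation therefore rests on one step only, and it points toward a weaker compound when the chlorophenyl is exchanged, though the thiophene is not the methoxyphenyl and the loss need not be as large.

Compound 4 is thus expected to give a higher number than compound 1, an estimated step of a 3.1-fold higher number from compound 1 to compound 4 (0.50 log units; beyond the scatter), landing at 6000 nM with a range from 2000 nM to 20000 nM.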

Compound 4, half-maximal inhibitory concentration: > 30000 nM
Compound 4: a limit, no number; the forecaster's own chance of this, stated with the estimate: 25%; middle value at least 5.0-fold (0.69 log units) from the limit.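

The step to thiophen-2-yl is an at least 15-fold higher number from compound 1 to compound 4 (1.19 log units; beyond the scatter), so a second and different exchange of the 4-chlorophenyl on the shared core now ends the same way as the methoxy exchange in compound 2. In this assay compound 4 gives > 30000 nM, which is a limit of the assay and not a number. The loss at this position is therefore no longer tied to one replacement, although compound 2 and compound 4 cannot be ranked against each other and the true size of neither loss can be read: the limit of > 30000 nM in this assay, at which 2 of the 4 values shown sit.

The compounds shown leave open whether any group at this position keeps a measurable number in this assay, for instance 4-bromophenyl, 4-fluorophenyl or 4-methylphenyl, and so whether the chloro group itself or the whole 4-chlorophenyl matters. They also leave open whether thiophen-2-yl would fare the same alongside the 4-methyl-1,3-thiazol-2-yl on the amide-type nitrogen, the group with which compound 3 gives 520 nM.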